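Carboxymethyl in place of 1-carboxyethyl on the shared core

The source may hold more compounds than are shown below. What is called first, only, known or untested is meant among the compounds shown, and "the series" means these compounds.

The series is read in a functional assay on CHO cells for antagonist activity at sphingosine 1-phosphate receptor 2 (Homo sapiens), read by calcium flux; on this read-out higher numbers stand for weaker inhibition and lower numbers for stronger inhibition. Three compounds have numbers. Compound 1 `O=C(Cc1nn(CC(=O)N2CCOCC2)c(=O)c2ccccc12)Nc1ccc(OC(F)(F)F)c(Cl)c1` gives 30 nM in this assay. Compound 2 `O=C(O)Cn1nc(Cc2nc3cc(Cl)c(OCC(F)F)cc3[nH]2)c2ccccc2c1=O` gives 12 nM in this assay. Compound 3 `C[C@@H](C(=O)O)c1nn(Cc2cn3cc(OCC4CC4)c(Cl)cc3n2)c2ccccc2c1=O` gives 24 nM in this assay. Compound 3 is thus placed with its gap to compound 1 within the usual scatter of repeated measurements, and its gap to compound 2 likewise within that scatter; the three numbers do not separate from one another on this read-out, and no ranking among them is supported.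

Compound 4 `O=C(O)Cc1nn(Cc2cn3cc(OCC4CC4)c(Cl)cc3n2)c2ccccc2c1=O` has not yet been measured. It differs from compound 3 in one place: hydrogen in place of methyl on a saturated chain carbon bound to an aromatic carbon and a carbonyl carbon; cut one bond further out, the same difference reads 1-carboxyethyl to carboxymethyl. Among the measured compounds shown here, no measured pair in this set carries this change, so no step size can be taken from the data; the numbers of compound 1, compound 2 and compound 3 all sit close together in this assay.

Compound 4 is expected to stay near the number of compound 3, with a step of a 1.2-fold higher number from compound 3 to compound 4 (0.07 log units; within the scatter) that is not expected to exceed the scatter in either direction. The estimate for compound 4 in this assay is 28 nM, with a range from 10 nM to 80 nM.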

Compound 4, half-maximal inhibitory concentration: 20 nM
Estimate against measurement, compound 4: 1.4-fold (0.15 log units) above, within the range that was stated.
By their numbers in this assay, from the lowest: compounds 2, 4, 3 and 1 (each within the scatter of the next, the first and the last beyond it).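

Working notes on the acid side chain: in this assay the change from 1-carboxyethyl to carboxymethyl gives a 1.2-fold lower number from compound 3 to compound 4 (0.08 log units; within the scatter) and is the only step in the series that reads this position on its own, a saturated chain carbon bound to an aromatic carbon and a carbonyl carbon. On this pair, the methyl can give way to hydrogen without a step beyond the scatter, so a number of this size does not depend on that one carbon, with compound 4 at 20 nM on the shared core. No measurement shown here bears on what lies behind this result.

What the compounds shown leave open is whether this carbon accepts anything larger than methyl, such as an ethyl group or a second methyl on the same carbon, and whether the opposite configuration of 1-carboxyethyl reads the same. Also open, from the compounds shown here alone, is whether the carboxylic acid itself can be exchanged at this position, for instance for a primary amide or a tetrazole, since this single pair keeps the acid throughout.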